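Nitro in Place of Methyl on an Aromatic Ring

The compounds below may be only part of what the source reports. "The series", "measured", "known", "first", "only" and "open" are said of these compounds alone.

In a functional assay on HCT-116 cells (Homo sapiens) for antiproliferative activity, read by MTT assay, with a stated time of 72 h (a higher number here means a weaker inhibitor, a lower number a stronger inhibitor), compound 1 (`COc1ccc(/C=C2/CN(C)/C(=N/c3ccc(C)cc3)S2)cc1`) gives 11100 nM and compound 2 (`COc1ccc(/C=C2\S/C(=N\c3ccc(C)c(Cl)c3)N(C)C2=O)cc1`) gives 14100 nM as its value. These two numbers lie within the usual scatter of each other, so compound 1 stands level with compound 2 and neither can be ranked over the other.

Compound 4 (`COc1ccc(/C=C2/CN(C)/C(=N/c3ccc([N+](=O)[O-])cc3)S2)cc1`) has not yet been measured. It keeps the core of compound 1 and changes one group: nitro in place of methyl on an aromatic carbon, para to a large group (nitro in place of methyl on an aromatic carbon). Among the compounds with values here, no two measured compounds here differ in one place only, so no measured step shows directly what this change does.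

Within the data shown here, the only caution comes from compound 3 (`COc1ccc(/C=C2\S/C(=N\c3cc(C(F)(F)F)cc(C(F)(F)F)c3)N(C)C2=O)cc1`), which stands at > 100000 nM as a limit of this assay and not as a number. That limit is the one reason to expect movement towards a higher number rather than a lower one, though it is weak support.

A small step towards a higher number is expected in this assay, near the edge of the usual scatter (a 2.0-fold higher number from compound 1 to compound 4 (0.30 log units; within the scatter)). For compound 4 the estimate is 22000 nM as a value, with an expected range from 8000 nM to 70000 nM around it.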

Compound 4, half-maximal inhibitory concentration: 10200 nM
Beside the measured number, compound 4's estimate is 2.2-fold (0.33 log units) above it, within the range that was stated.
By their numbers in this assay, from the lowest: compounds 4, 1 and 2 (each within the scatter of the next). At a limit, above all of these: compound 3.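

Within the data shown here, the first pair here that differs in one place only now exists, and in this assay nitro in place of methyl on an aromatic carbon, para to a large group, gives a 1.1-fold lower number from compound 1 to compound 4 (0.04 log units; within the scatter) and so no difference that can be told apart from repeat measurements. Among these compounds, at this position, then, the single methyl and the larger nitro, which adds hydrogen-bond acceptors that the methyl lacks, leave the compound level in this cell test, something the earlier compounds could not show. Compound 3 stays a limit and not a number, and it differs from compound 4 in more than one place, so this step says nothing about it: the limit of > 100000 nM in this assay, at which 1 of the 4 values shown sits.

Going by these compounds, what an amine or a carboxylic acid at this same position would give stays open, as does whether a longer chain there would keep the value level. Also open, on these data alone, is whether the same swap would read the same way on the core of compound 2, which carries a carbonyl, or in a different cell line.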